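Ethyl to isopropyl carbamate on a shared kinase inhibitor core

The source may hold more compounds than are shown below. What is called first, only, known or untested is meant among the compounds shown, and "the series" means these compounds.

Measured compounds:
compound 1, `CC(OC(=O)N1CCN(C(=O)c2nc(Nc3cc(C4CC4)[nH]n3)c3cc(Cl)ccc3n2)C[C@H]1C)OC(=O)C(C)(C)C`, 23.6%
compound 2, `C[C@@H]1CN(C(=O)c2nc(Nc3cc(C4CC4)[nH]n3)c3cc(Cl)ccc3n2)CCN1C(=O)OCOC(=O)C(C)(C)C`, 24.1%
compound 3, `CCOC(=O)N1CCN(C(=O)c2nc(Nc3cc(C4CC4)[nH]n3)c3cc(Cl)ccc3n2)C[C@H]1C`, 79.2%

Three compounds share a core and differ only in the group attached to the carbamate oxygen. In an assay for inhibition of serine/threonine-protein kinase PAK 4 (Homo sapiens), read by FRET and Z'-LYTE, with a stated time of 60 min, tested at 5 uM, in the presence of a further agent that is not named here (on this read-out higher numbers stand for a stronger effect at the one concentration tested and lower numbers for a weaker effect), compound 3 gives 79.2%, the highest of the three numbers. Compound 2 gives 24.1% and compound 1 gives 23.6% in this assay.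

The two cores of compound 2 and compound 3 differ by methyl in place of ((tert-butyl)carbonyl)oxy on a saturated chain carbon bound to an oxygen next to a carbonyl group. That exchange made a large step: a number 55.1 percentage points higher from compound 2 to compound 3 (beyond the scatter), and the related pair shows a number 55.6 percentage points higher from compound 1 to compound 3 (beyond the scatter).

Within the pair of compound 2 and compound 1 the change is methyl in place of hydrogen on a saturated chain carbon bound to two oxygens next to a carbonyl group. Its step was a number 0.5 percentage points lower from compound 2 to compound 1 (within the scatter).

Compound 4, `CC(C)OC(=O)N1CCN(C(=O)c2nc(Nc3cc(C4CC4)[nH]n3)c3cc(Cl)ccc3n2)C[C@H]1C`, has not yet been measured in this assay. It differs from compound 3 by methyl in place of hydrogen on a saturated chain carbon bound to an oxygen next to a carbonyl group and a saturated chain carbon. This is the same kind of change as that from compound 2 to compound 1, but not the same: there the carbon carrying the new methyl was bound to two oxygens, here it is bound to an oxygen and a saturated chain carbon. Going by the values given here, on the single earlier example the step was within the scatter, so a similarly small step is expected here, while the different surroundings leave room for a modest shift. The expected step from compound 3 to compound 4 is a number 7.2 percentage points lower from compound 3 to compound 4 (within the scatter), because the earlier step of a number 0.5 percentage points lower from compound 2 to compound 1 (within the scatter) was small. Compound 4 is estimated to give 72% in this assay, within a range from 50% to 90%.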

Compound 4, a percentage reported as inhibition, at one concentration (the size of the read-out at that concentration, not a potency): 75.8%
For compound 4 the middle estimate is 3.8 percentage points below the measured one; the range from low to high includes it.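

In this assay, the extra methyl that turns ethyl into isopropyl gives a number 3.4 percentage points lower from compound 3 to compound 4 (within the scatter), and this small step matches the one seen when the same kind of methyl is added on the other carbamate: the same change on two cores in this assay, a number 0.5 percentage points lower (within the scatter) from compound 2 to compound 1 and a number 3.4 percentage points lower (within the scatter) from compound 3 to compound 4, 2.9 percentage points apart, within the scatter of two such steps. The large gain also holds up across the series, with a number 51.7 percentage points higher from compound 2 to compound 4 (beyond the scatter) and a number 52.2 percentage points higher from compound 1 to compound 4 (beyond the scatter), so the compounds carrying the ((tert-butyl)carbonyl)oxy group sit well under those without it whichever partner is compared: the same change on two cores in this assay, a number 55.1 percentage points higher (beyond the scatter) from compound 2 to compound 3 and a number 52.2 percentage points higher (beyond the scatter) from compound 1 to compound 4, 2.9 percentage points apart, within the scatter of two such steps. This shows that, among these four compounds, the two changes behave alike from one carbamate to the next, but it rests on only two pairs for each change, at a single concentration, so it gives no measure of potency, does not show that the methyl has no effect at all, and does not explain why the ((tert-butyl)carbonyl)oxy compounds give lower numbers.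

The compounds shown leave open how far the carbamate oxygen tolerates larger groups, such as a longer chain like n-butyl or a tert-butyl group. They also leave open what happens when the carbamate itself gives way to a simple amide or a free amine.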